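Chalcone series: aryl ketone substituent and antiproliferative potency

A few compounds are considered here, and "the series" means these few. Any claim that something is new, unique, unknown or untested is made for them only; others in the source may bear on it.

Compound 3 `COc1ccc(/C=C/c2cc(OC)cc(OC)c2/C=C/C(=O)c2ccc(OC)cc2)cc1` gives 5.8 ug/mL in a functional assay on B16-F10 cells (Mus musculus) for antiproliferative activity, read by MTT assay, with a stated time of 48 h; on this read-out higher numbers stand for weaker inhibition and lower numbers for stronger inhibition. On the numbers shown it stands second highest of the three: compound 1 `CCOc1ccc(C(=O)/C=C/c2c(/C=C/c3ccc(OC)cc3)cc(OC)cc2OC)cc1` gives 6.4 ug/mL, and a 1.1-fold lower number from compound 1 to compound 3 (0.04 log units; within the scatter), so these two cannot be told apart; compound 2 `COc1ccc(/C=C/c2cc(OC)cc(OC)c2/C=C/C(=O)c2ccc(C)c(C)c2)cc1` gives 1.4 ug/mL, and a 4.1-fold higher number from compound 2 to compound 3 (0.62 log units; beyond the scatter).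

Compound 4 `COc1ccc(/C=C/c2cc(OC)cc(OC)c2/C=C/C(=O)c2ccc(-c3ccccc3)cc2)cc1` differs from compound 3 in one place: phenyl in place of methoxy on an aromatic carbon.

The bearing steps are the two that exchange the group on the carbonyl-bound ring. Replacing 4-ethoxyphenyl with 3,4-dimethylphenyl gave a 4.6-fold lower number from compound 1 to compound 2 (0.66 log units; beyond the scatter), and returning from carbon-only substitution to 4-methoxyphenyl gave a 4.1-fold higher number from compound 2 to compound 3 (0.62 log units; beyond the scatter). The ethoxy-to-methoxy step, a 1.1-fold lower number from compound 1 to compound 3 (0.04 log units; within the scatter), lay within the scatter. Thus exchanging an alkoxy for a carbon-only group lowered the number modestly, while alkoxy size did not matter. Phenyl is a further carbon-only group without an acceptor, so a modest lowering is expected, with wide uncertainty since no biaryl has been measured.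

Compound 4 is therefore estimated at 2.5 ug/mL in this assay, within 0.8 ug/mL to 8 ug/mL, which is expected to mean a 2.3-fold lower number from compound 3 to compound 4 (0.37 log units; beyond the scatter).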

Compound 4, half-maximal inhibitory concentration: 10.6 ug/mL
Beside the measured number, compound 4's estimate is 4.2-fold (0.63 log units) below it, and the stated range ends below it.
By their numbers in this assay, from the lowest: compound 2; then compounds 3, 1 and 4 (each within the scatter of the next).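

In this assay, the phenyl-for-methoxy exchange on this aromatic carbon gives a 1.8-fold higher number from compound 3 to compound 4 (0.26 log units; within the scatter) and the phenyl-for-ethoxy exchange gives a 1.7-fold higher number from compound 1 to compound 4 (0.22 log units; within the scatter), so compound 4 cannot be told apart from either alkoxy compound. Compound 4 therefore goes against the earlier reading that a carbon-only group lowers the number, while compound 2 stays apart, with a 7.6-fold higher number from compound 2 to compound 4 (0.88 log units; beyond the scatter) as the step to the 4-phenylphenyl group. The data on hand offer no explanation for the gap between these two carbon-only groups.

Open, on these data alone, is whether a lone methyl at this place would fall with compound 2 or with compound 4. Also open, as far as these compounds go, is how an amine or a carboxylic acid at this place would read out.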